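Chloro for hydrogen on the phenyl of compound 3

The compounds below may be only part of what the source reports. "The series", "measured", "known", "first", "only" and "open" are said of these compounds alone.

Compound 1 `N#Cc1ccc(-c2cnc3[nH]cc(-c4nnc(-c5ccc(F)cc5)o4)c(=O)c3c2)cc1` gives 10.2% in a functional assay on HCT-116 cells (Homo sapiens) for inhibition, read by MTT assay, with a stated time of 24 h, tested at 2.5 uM; a higher number here means more inhibition of growth at the concentration tested, a lower number less inhibition of growth. Compound 2 `CS(=O)(=O)c1ccc(-c2cnc3[nH]cc(-c4nnc(-c5ccncc5)o4)c(=O)c3c2)cc1` gives 2.64%, and compound 3 `CS(=O)(=O)c1ccc(-c2cnc3[nH]cc(-c4nnc(-c5ccccc5)o4)c(=O)c3c2)cc1` gives 0.53%. Among the compounds with values here, compound 3 carries the lowest of the three numbers, yet its gaps to compound 2 and to compound 1 both lie within the scatter; the one single-point step, a number 2.1 percentage points lower from compound 2 to compound 3 (within the scatter), phenyl in place of pyridin-4-yl on an aromatic carbon, also stays within the scatter. Compound 4 `CS(=O)(=O)c1ccc(-c2cnc3[nH]cc(-c4nnc(-c5ccc(Cl)cc5)o4)c(=O)c3c2)cc1` differs from compound 3 by chloro in place of hydrogen on an aromatic carbon. Within the data shown here, no measured step exchanges hydrogen for chloro; the one halogen-bearing member, compound 1, differs in two places and itself sits within the scatter of compound 3. For compound 4 no step beyond the scatter is expected, a number 2.5 percentage points higher from compound 3 to compound 4 (within the scatter). Compound 4 is estimated at 3%, range 0% to 12%.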

Compound 4, percent growth inhibition at one concentration: 2.06%
Compound 4: the middle estimate sits 0.9 percentage points above what was measured, within the range that was stated.
By their numbers in this assay, from the lowest: compounds 3, 4, 2 and 1 (each within the scatter of the next).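

Chloro in place of hydrogen, para to a large group on the phenyl, gives a number 1.5 percentage points higher from compound 3 to compound 4 (within the scatter) in this assay, the first direct reading of a halogen at this position. Against the other neighbour, 4-chlorophenyl in place of pyridin-4-yl gives a number 0.6 percentage points lower from compound 2 to compound 4 (within the scatter), so phenyl, 4-chlorophenyl and pyridin-4-yl cannot be told apart here. No measurement available bears on these steps.

As far as these compounds go, whether an amine or a carboxylic acid at this position would give a step beyond the scatter remains open.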